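The source may hold more compounds than are shown below. What is called first, only, known or untested is meant among the compounds shown, and "the series" means these compounds.

Going by the values given here, compound 1, `C#CCSC(=O)/C=C(C)/C=C/CC(C)CCCC(C)C`, sits with a reading of 5.07 in a physicochemical assay for lipophilicity (a lower number here means a more polar compound, a higher number a more lipophilic compound), the one number recorded for it there, alongside a further entry that gives no single figure. Compound 2, `CCC(=O)/C=C(C)/C=C/CC(C)CCCC(C)C`, is the other measured member of the set; in this assay compound 2 gives 6.27; 6.68 (2 entries), and the spread of those repeats (the several entries of compound 2 in this assay, 6.27; 6.68 (2 entries)) shows how much the reading of one compound can wander. Compound 3, `CC(/C=C/CC(C)CCCC(C)C)=C\C(=O)c1ccccc1`, has not yet been measured. Against compound 1 it differs at one place: phenyl in place of propargylsulfanyl on a carbonyl carbon. Among the compounds with values here, no directly comparable measured pair exists for this change, so the size of the step rests on expectation alone. Compound 3 is expected to read higher than compound 1 in this assay, a step from compound 1 to compound 3 estimated at a number 1.83 log units higher from compound 1 to compound 3 (beyond the scatter). Compound 3 is therefore estimated at 6.9, with a likely range from 6 to 7.8.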

Compound 3, partition coefficient: 7.26
The estimate for compound 3 lay 0.36 log units below the measured number; measured number inside the range.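

With compound 3, the carbonyl carbon gains its first measured step in this set: in this assay, phenyl in place of propargylsulfanyl gives a number 2.19 log units higher from compound 1 to compound 3 (beyond the scatter). Going by these compounds alone, until now, the set held no measured step between two compounds, so the size of any change at this place had rested on expectation alone. The step is clearly wider than the wander seen between repeated readings of a single compound: the several entries of compound 2 in this assay, 6.27; 6.68 (2 entries)

The compounds shown cannot separate what the entering phenyl contributes from what the departure of propargylsulfanyl contributes, as both occur in this single exchange. They also leave open how an amine, a carboxylic acid or a pyridine ring on the same carbonyl carbon would read in this assay.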